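Moving the Pyridine Nitrogen in a Carboxylic Acid Ketone

The source may hold more compounds than are shown below. What is called first, only, known or untested is meant among the compounds shown, and "the series" means these compounds.

Compound 1 `NC(=O)c1ccc(-c2cnc(C(O)CCc3ccc(-c4ccccc4)cc3)o2)nc1` and compound 2 `O=C(O)c1ccc(-c2cnc(C(=O)CCc3ccc(-c4ccccc4)cc3)o2)cn1` share a core that carries a biphenyl chain. In an assay for inhibition of Fatty-acid amide hydrolase 1 (Rattus norvegicus) (on this read-out lower numbers stand for stronger inhibition and higher numbers for weaker inhibition), compound 1 gives > 1000 nM, which is a limit of the assay and not a number. In this assay, within the data shown here, compound 2 gives 44 nM, the only number measured here. Compound 3 `O=C(O)c1ccc(-c2cnc(C(=O)CCc3ccc(-c4ccccc4)cc3)o2)nc1` differs from compound 2 by 5-carboxypyridin-2-yl in place of 6-carboxypyridin-3-yl on an aromatic carbon. Among the measured compounds shown here, with no measured step of this kind to lean on, the change from compound 2 to compound 3 is expected to stay within the scatter, as a 1.4-fold higher number from compound 2 to compound 3 (0.13 log units; within the scatter). Compound 3 is therefore estimated at 60 nM, between 15 nM and 250 nM.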

Compound 3, inhibition constant: 14 nM
Compound 3: the middle estimate sits 4.3-fold (0.63 log units) above what was measured; measured number outside the range, below it.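

With the same atoms joined differently, this position on the shared core proves sensitive to the arrangement inside the pyridine ring alone: in this assay the change gives a 3.1-fold lower number from compound 2 to compound 3 (0.50 log units; beyond the scatter) for the ketone acid pair. Moving the ring nitrogen, with no atom added or lost, is therefore enough to shift the number beyond the usual scatter. Nothing in the data given here explains why this rearrangement lowers the number.

Going by these compounds, whether a phenyl ring carrying the carboxylic acid would serve here stays open. So does the effect of a methyl ester in place of the acid on the better ring.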